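A Dimethoxyphenyl Aniline Variant of Compound 1

A few compounds are considered here, and "the series" means these few. Any claim that something is new, unique, unknown or untested is made for them only; others in the source may bear on it.

Measured so far:
Compound 1 `O=C(/C=C\Nc1ccc(F)cc1)c1nc(-c2ccc(F)cc2)n2ccccc12` gives 13200 nM in a functional assay on A549 cells (Homo sapiens) for cytotoxicity, read by MTT assay, with a stated time of 48 h; on this read-out higher numbers stand for weaker inhibition and lower numbers for stronger inhibition.
Compound 2 `O=C(/C=C\Nc1ccc(F)cc1)c1nc(-c2ccc(C(F)(F)F)cc2)n2ccccc12` gives only a limit, > 30000 nM, in this assay.

Among the measured compounds shown here, compound 1 stands as the only finished number among the two measured compounds. The value of compound 2 is a limit of the assay, not a number (the limit of > 30000 nM in this assay, at which 1 of the 2 values shown sits). For the measured compounds named here, the one measured step, an at least 2.2-fold higher number from compound 1 to compound 2 (0.35 log units; beyond the scatter), changes the ring attached to the shared core, not the ring on the amine nitrogen. Compound 3 `COc1ccc(N/C=C\C(=O)c2nc(-c3ccc(F)cc3)n3ccccc23)cc1OC` differs from compound 1 at that other place: 3,4-dimethoxyphenyl in place of 4-fluorophenyl on an amine nitrogen. Going by the values given here, no measured step touches this position, so the measured step gives no direct guide, and the expectation rests on the value of compound 1 alone. Compound 3 is therefore expected to sit close to compound 1, with the step of a 1.1-fold lower number from compound 1 to compound 3 (0.04 log units; within the scatter) meant as no change beyond the scatter. The estimate for compound 3 in this assay is 12000 nM, within 4000 nM to 30000 nM.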

Compound 3, half-maximal inhibitory concentration: > 30000 nM
Compound 3 was reported as a limit; the forecaster's own chance of this, stated with the estimate: 25%; middle value at least 2.5-fold (0.39 log units) from the limit.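

The ring on the amine nitrogen is not a position that tolerates any change: putting 3,4-dimethoxyphenyl in place of 4-fluorophenyl gives an at least 2.2-fold higher number from compound 1 to compound 3 (0.35 log units; beyond the scatter) in this assay. Among the compounds shown here, the only earlier step changed the ring attached to the shared core, so this is the first sign that the ring on the amine nitrogen also affects this read-out. The value of compound 3 is a limit and not a number, so the step gives only a minimum size, and the limit now holds most of the values shown: the limit of > 30000 nM in this assay, at which 2 of the 3 values shown sit.

On these data alone, whether the change comes from losing the fluoro group or from adding the methoxy groups stays open, as compound 3 does both at once. The compounds shown also leave open how an unsubstituted phenyl, or a phenyl carrying a single methoxy group or an amine, would behave on this nitrogen.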